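Guanidine Series for SUR2/Kir6.2: Chain Extension on Compound 2

A few compounds are considered here, and "the series" means these few. Any claim that something is new, unique, unknown or untested is made for them only; others in the source may bear on it.

Compounds measured so far:
- compound 1, `CC(C)(C)C(NC(=O)c1ccc(Cl)cc1)N/C(S)=N/c1cccnc1`: 2510 nM
- compound 2, `CC(C)(C)C(NC(=O)c1ccc(Cl)cc1)N/C(=N/c1cccnc1)NC#N`: 6310 nM
- compound 3, `CC(C)(C)C(NC(=O)c1ccc(Cl)cc1)N/C(=N/c1cccnc1)N[N+](=O)[O-]`: 31600 nM

All three share one core and differ only at the carbon that carries a double bond to nitrogen. In a functional assay with sulfonylurea receptor 2, Kir6.2 (Homo sapiens) as the target (on this read-out higher numbers stand for an effect only at larger amounts of compound and lower numbers for an effect already at smaller amounts), compound 2 gives 6310 nM, the second highest of the three numbers. Its nearest neighbour is compound 1, reached by a 2.5-fold higher number from compound 1 to compound 2 (0.40 log units; beyond the scatter). Its furthest neighbour is compound 3, reached by a 5.0-fold higher number from compound 2 to compound 3 (0.70 log units; beyond the scatter). The remaining step is a 13-fold higher number from compound 1 to compound 3 (1.10 log units; beyond the scatter).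

Compound 4, `C=CCC(C)(C)C(NC(=O)c1ccc(Cl)cc1)N/C(=N/c1cccnc1)NC#N`, is not yet measured. It differs from compound 2 by vinyl in place of hydrogen on a saturated chain carbon, three bonds along the chain from an amide-type nitrogen and an amine nitrogen, that is, methyl becomes allyl and tert-butyl becomes 1,1-dimethylbut-3-en-1-yl.

For the measured compounds named here, none of the measured steps touches this part of the molecule: every one of them changes the group on the carbon with the double bond to nitrogen, while the tert-butyl is kept in all three compounds. Going by the values given here, there is therefore no measured step that bears on the change from compound 2 to compound 4, and no direction can be read from the numbers. The most reasonable expectation is a step of a 1.0-fold lower number from compound 2 to compound 4 (0.00 log units; within the scatter), not beyond the scatter. Compound 4 is thus estimated at 6300 nM in this assay, within a range from 2000 nM to 20000 nM.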

Compound 4, half-maximal effective concentration: 20000 nM
The estimate for compound 4 lay 3.2-fold (0.50 log units) below the measured number, and the stated range covers the measured number.
By their numbers in this assay, from the lowest: compound 1; then compound 2; then compounds 4 and 3 (each within the scatter of the next).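

Until this point, every measured change sat on the carbon with the double bond to nitrogen, so the tert-butyl group had stayed untested. For the compounds shown here, compound 4 changes that group for the first time, and in this assay going to 1,1-dimethylbut-3-en-1-yl gives a 3.2-fold higher number from compound 2 to compound 4 (0.50 log units; beyond the scatter), so more compound is needed for the same effect and this part of the molecule clearly influences the read-out. The data shown offer no explanation for this shift.

One open question is whether the rise comes from the longer chain or from its double bond, and a saturated 1,1-dimethylbutyl group in the same place would help to separate the two. Going by these compounds, it is also open how a shorter ethyl in place of the methyl would behave, how a hydroxyl or an amine at the end of the chain would behave, and whether the same chain extension would give a similar step when the cyanoamino group is replaced by the sulfanyl group of compound 1 or the nitroamino group of compound 3.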